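The compounds below may be only part of what the source reports. "The series", "measured", "known", "first", "only" and "open" are said of these compounds alone.

Measured in a functional assay on 786-0 cells (Homo sapiens) for inhibition, read by sulforhodamine B assay, with a stated time of 48 h; a lower number here means a stronger inhibitor of growth, a higher number a weaker inhibitor of growth:

- Compound 1 `CCOC(=O)c1nn(-c2ccccc2)c(-c2ccccc2)c1CNC(C)(C)C`: 144000 nM; 42400 nM (2 entries)
- Compound 2 `CC(C)(C)NCc1c(C(=O)O)nn(-c2ccccc2)c1-c1ccccc1`: > 716000 nM (a limit)
- Compound 3 `COc1ccc(-c2c(CNC(C)(C)C)c(C(=O)O)nn2-c2ccccc2)cc1`: > 659000 nM (a limit)

Compound 2 has no number in this assay. Its entry of > 716000 nM is a limit. Compound 3 is also known only as a limit, > 659000 nM. Compound 1 is the only one of the three with numbers, 144000 nM; 42400 nM (2 entries).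

Compound 4 `CC(C)(C)NCc1c(C(=O)O)nn(-c2ccc(Cl)cc2)c1-c1ccccc1` differs from compound 2 by chloro in place of hydrogen on an aromatic carbon, para to a large group, so that phenyl becomes 4-chlorophenyl: chloro in place of hydrogen on an aromatic carbon. Going by the values given here, the one measured step that bears on this is a step that the two limits leave unreadable from compound 2 to compound 3, with methoxy in place of hydrogen on an aromatic carbon. That step offers no size to carry over, so no step beyond the scatter is expected in this assay, in either direction, and another limit is the likeliest report. The expected step is an at least 1.1-fold lower number from compound 2 to compound 4 (0.04 log units; that floor lies within the scatter). Compound 4 is estimated at 650000 nM, with an expected range of 300000 nM to 1000000 nM.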

Compound 4, concentration for 50% growth inhibition: > 652000 nM
Compound 4 gave a limit, no number (the forecaster's own chance of this, stated with the estimate: 75%); middle value at least 1.0-fold (0.00 log units) away from the limit.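

Compound 2 and compound 4 are both known only as limits in this assay, and no step can be read between them. The compounds shown leave open whether chloro or methoxy in place of hydrogen on an aromatic carbon of compound 2 changes growth inhibition at all.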